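Anilino-pyrimidine nitriles: methoxy-to-methyl step on the aniline

The source may report more compounds than this note shows. Statements on the series, on what has been measured and on what is new or still open speak of the compounds shown alone.

Measured so far:
compound 1, `C#CCSc1nc(Nc2ccccc2Cl)c(C#N)c(-c2ccccc2)n1`, 24200 nM
compound 2, `COc1ccccc1Nc1nc(SCc2cn(Cc3ccccc3Cl)nn2)nc(-c2ccccc2)c1C#N`, 6170 nM

In a functional assay on MCF7 cells (Homo sapiens) for inhibition, read by MTT assay, with a stated time of 72 h (on this read-out higher numbers stand for weaker inhibition and lower numbers for stronger inhibition), compound 2 gives the lower of the two numbers recorded; compound 1 gives a number that stands beyond the scatter above it. The two share a core but differ in more than one place, so what lies between them cannot be assigned to a single change.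

Compound 3, `Cc1ccccc1Nc1nc(SCc2cn(Cc3ccccc3Cl)nn2)nc(-c2ccccc2)c1C#N`, differs from compound 2 in a single spot: methyl in place of methoxy on an aromatic carbon. Going by the values given here, no pair of measured compounds shows this change in isolation, so there is no step to lean on. With a group of similar size put in the same spot, the expectation is a step of no size beyond the scatter, in no fixed direction, which is what a 1.0-fold lower number from compound 2 to compound 3 (0.01 log units; within the scatter) expresses. Compound 3 is therefore estimated at 6000 nM in this assay, with a range from 2500 nM to 15000 nM.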

Compound 3, half-maximal inhibitory concentration: 7950 nM
Compound 3: middle estimate off by 1.3-fold (0.12 log units), on the low side, and the stated range covers the measured number.
By their numbers in this assay, from the lowest: compounds 2 and 3 (each within the scatter of the next); then compound 1.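

In this assay, the series now has its first step that can be read at a single place: a 1.3-fold higher number from compound 2 to compound 3 (0.11 log units; within the scatter). On this ortho position, with a large group alongside the substituent's aromatic carbon, methoxy and methyl therefore give numbers that cannot be told apart, so in this pair the hydrogen-bond acceptor that leaves with the methoxy is not needed to keep the number at this level. No supporting measurement bears on the reason for this result.

As far as these compounds go, whether a quite different group in this spot, such as an amine, a carboxylic acid or a longer alkoxy chain, would separate from methoxy and methyl remains open. The steps from compound 1 to compound 2 and compound 3 cannot be read, since those compounds differ in more than one place.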